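This account rests on a few compounds, and the source may have more. Where it says the series, first, only, none or still open, it means among the compounds named here.

Three compounds have been measured in a physicochemical assay for lipophilicity; on this read-out higher numbers stand for higher lipophilicity and lower numbers for lower lipophilicity:

- compound 1 `CCCCCCN(CCCCCSc1nc2ccccc2o1)C(=O)Nc1ccc(F)cc1F` (7.18)
- compound 2 `CCCCCCN(CCOCCSc1nc2c[nH]cnc-2n1)C(=O)Nc1ccc(F)cc1F` (4.32)
- compound 3 `CCCCCCCN(CCCCCSc1ncccn1)C(=O)Nc1ccc(F)cc1F` (5.41)

Compound 3 stands second highest of the three on this assay. It lies beyond the scatter from both neighbours, closer to compound 2 and further from compound 1.

The next compound is compound 4 `CCCCCCCN(CCCCCSc1[nH]cnc2ncnc1-2)C(=O)Nc1ccc(F)cc1F`, not yet measured. It keeps the heptyl chain and the rest of compound 3 but exchanges the pyrimidin-2-yl on the sulfur for a larger group with no common name (a group of 9 heavy atoms (5 carbon, 4 nitrogen; one five-membered aromatic ring with 2 hetero atoms, one six-membered aromatic ring with 2 hetero atoms) in place of a group of 6 heavy atoms (4 carbon, 2 nitrogen; one six-membered aromatic ring with 2 hetero atoms), on a sulfur).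

For the measured compounds named here, no measured pair of compounds differs in one place only, so the size of this step has no direct precedent. The nearest guide is weak. Compound 1 (7.18) and compound 2 (4.32) each carry a two-ring group on the sulfur, yet they fall on opposite sides of compound 3 (5.41), and they also differ from it elsewhere. These values therefore point to no large step in either direction.

A slight rise, within the scatter, is expected, and the estimated step is small (a number 0.19 log units higher from compound 3 to compound 4 (within the scatter)). For compound 4 the expected value is 5.6 (estimated range 4.9 to 6.3).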

Compound 4, partition coefficient: 5.32
The estimate for compound 4 lay 0.28 log units above the measured number; the range from low to high includes it.
By their numbers in this assay, from the lowest: compound 2; then compounds 4 and 3 (each within the scatter of the next); then compound 1.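

In this assay, for the compounds shown here, the exchange of the pyrimidin-2-yl on the sulfur for the larger two-ring group gives the first step in this set that changes one place only: a number 0.09 log units lower from compound 3 to compound 4 (within the scatter). Going by these compounds alone, at this position, then, a group with three more heavy atoms, a second aromatic ring and one hydrogen-bond donor in place of none leaves the read-out within the usual scatter, which the earlier compounds, all differing in more than one place, could not show. Nothing measured here bears on why the read-out stays within the scatter across this exchange.

This single pair leaves open whether the same holds for other groups on the sulfur, such as a phenyl ring, a carboxylic acid or an amine, which might give a step beyond the scatter in this assay. It also leaves open whether the two-ring group would give a similar step with the hexyl chain in place of the heptyl chain, or with an ether in the chain that leads to the sulfur.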